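The source may hold more compounds than are shown below. What is called first, only, known or untested is meant among the compounds shown, and "the series" means these compounds.

Compound 1 `CCOC(=O)NS(=O)(=O)c1sc(CC(C)C)cc1-c1cccc(Cn2ccnc2)c1`: 300 nM
Compound 2 `CC(C)Cc1cc(-c2cccc(Cn3ccnc3)c2)c(S(=O)(=O)NC(=O)OC(C)C)s1`: 160 nM
Compound 3 `COCCOC(=O)NS(=O)(=O)c1sc(CC(C)C)cc1-c1cccc(Cn2ccnc2)c1`: 480 nM

In an assay on HEK293 cells for displacement of a labelled ligand from Type-2 angiotensin II receptor (Homo sapiens), read by scintillation counting, with a stated time of 240 min (on this read-out higher numbers stand for weaker inhibition and lower numbers for stronger inhibition), compound 3 stands at the highest of the three numbers. Its nearest neighbour is compound 1, with a step of a 1.6-fold higher number from compound 1 to compound 3 (0.20 log units; within the scatter); the step of a 3.0-fold higher number from compound 2 to compound 3 (0.48 log units; beyond the scatter) lies beyond the scatter. Compound 4 `CCCC(=O)NS(=O)(=O)c1sc(CC(C)C)cc1-c1cccc(Cn2ccnc2)c1` differs from compound 3 by propyl in place of 2-methoxyethoxy on a carbonyl carbon. Within the data shown here, none of the measured steps reaches the carbonyl carbon: all three change only the group on the oxygen next to a carbonyl group, and they stay small, a 1.9-fold lower number from compound 1 to compound 2 (0.27 log units; within the scatter) and a 1.6-fold higher number from compound 1 to compound 3 (0.20 log units; within the scatter) within the scatter, a 3.0-fold higher number from compound 2 to compound 3 (0.48 log units; beyond the scatter) modest. The change to compound 4 is therefore not covered by the measured steps, and no step beyond the scatter is expected in this assay. Compound 4 is estimated at 350 nM (range 120 nM to 1000 nM), which means an expected step of a 1.4-fold lower number from compound 3 to compound 4 (0.14 log units; within the scatter).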

Compound 4, inhibition constant: 300 nM
Beside the measured number, compound 4's estimate is 1.2-fold (0.07 log units) above it; measured number inside the range.
By their numbers in this assay, from the lowest: compounds 2, 1, 4 and 3 (each within the scatter of the next, the first and the last beyond it).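

Compound 4 shows that in this assay the carbonyl carbon need not carry a group bound through oxygen: propyl in place of 2-methoxyethoxy stays within the scatter (a 1.6-fold lower number from compound 3 to compound 4 (0.20 log units; within the scatter)), as does propyl in place of isopropoxy (a 1.9-fold higher number from compound 2 to compound 4 (0.27 log units; within the scatter)) or ethoxy (no change at the digits printed from compound 1 to compound 4 (within the scatter)). No evidence is available to explain this result. The compounds shown leave open whether an amine, a carboxylic acid or a longer chain on this carbonyl carbon would stay as close, and whether propyl would behave alike with a change elsewhere on the shared core.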